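The source may report more compounds than this note shows. Statements on the series, on what has been measured and on what is new or still open speak of the compounds shown alone.

Series notes on the shared core of compound 2, `CSc1nc(NCc2ccccc2)c2ccccc2n1`. In an ADME assay on 184B5 cells (Homo sapiens) for cytotoxicity, read by MTT assay, with a stated time of 72 h (a higher number here means a weaker inhibitor of growth, a lower number a stronger inhibitor of growth), compound 2 gives > 100000 nM, which is a limit of the assay rather than a number. Within the data shown here, compound 1, `CSc1nc(NCc2ccc([Se]C)cc2)c2ccccc2n1`, is the only other measured member. In this assay compound 1 gives > 100000 nM, again a limit of the assay. Among the measured compounds shown here, the step that the two limits leave unreadable from compound 1 to compound 2 is therefore unreadable, and the sole evidence bearing on the next change is the limit of > 100000 nM in this assay, at which 2 of the 2 values shown sit. The next compound, compound 3, `CSc1ccc(CNc2nc(SC)nc3ccccc23)cc1`, differs from compound 2 by methylsulfanyl in place of hydrogen on an aromatic carbon. For the measured compounds named here, no measured step reports a readable size for a change at this place, so no step beyond the scatter is expected in this assay, and the reading is expected to stay at the limit. The expected step that the limit leaves unreadable from compound 2 to compound 3 is accordingly negligible. Compound 3 is estimated at 150000 nM, with a range of 50000 nM to 500000 nM in this assay.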

Compound 3, concentration for total growth inhibition: > 100000 nM
Compound 3 ended at the assay's limit (the forecaster's own chance of this, stated with the estimate: 85%); the middle value lies beyond the limit too.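

Compound 3 joins compound 1 and compound 2 at a limit of the assay, so no step among the three can be read: the limit of > 100000 nM in this assay, at which 3 of the 3 values shown sit.

The compounds shown leave open whether methylsulfanyl in place of hydrogen, or any other change here, alters growth inhibition by a readable amount.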